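This account rests on a few compounds, and the source may have more. Where it says the series, first, only, none or still open, it means among the compounds named here.

Compound 1 `CCc1nn2c(C)cc(C)nc2c1Cc1ccc(/C=C/CN2CCNC(=O)C2)cc1` — 27 nM
Compound 2 `CCc1nn2c(C)cc(C)nc2c1Cc1ccc(/C=C/CN2CCN(C(C)C)CC2)cc1` — 43 nM

Among the measured compounds shown here, in a functional assay on HeLa cells for antagonist activity at G-prodeshotein coupled receptor 4 (Homo sapiens), read by HTRF and cAMP accumulation, with a stated time of 15 min (on this read-out higher numbers stand for weaker inhibition and lower numbers for stronger inhibition), compound 2 gives 43 nM, the highest of the two numbers so far; its nearest neighbour is compound 1 with 27 nM, and the step of a 1.6-fold higher number from compound 1 to compound 2 (0.20 log units; within the scatter) lies within the scatter, so the two cannot be ranked. Compound 3 `CCc1nn2c(C)cc(C)nc2c1Cc1ccc(/C=C/CN2CCNCC2=O)cc1` has not yet been measured. Its structure differs from compound 2 in one place: 2-oxopiperazin-1-yl in place of 4-isopropylpiperazin-1-yl on a saturated chain carbon bound to a double-bonded chain carbon.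

For the measured compounds named here, only one measured step bears on this change. The step of a 1.6-fold higher number from compound 1 to compound 2 (0.20 log units; within the scatter) replaced an oxopiperazinyl ring by the 4-isopropylpiperazin-1-yl ring at the same place and stayed within the scatter. Compound 3 reverses that kind of exchange, bringing back a ring with one hydrogen-bond donor and a carbonyl. No step beyond the scatter is therefore expected; the estimated step is a 1.4-fold lower number from compound 2 to compound 3 (0.16 log units; within the scatter). Compound 3 is estimated to give 30 nM, within a range from 12 nM to 75 nM.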

Compound 3, half-maximal inhibitory concentration: 73 nM
Compound 3: the middle estimate sits 2.4-fold (0.39 log units) below what was measured; low and high end bracket the measured number.
By their numbers in this assay, from the lowest: compounds 1, 2 and 3 (each within the scatter of the next, the first and the last beyond it).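

In this assay the change from 3-oxopiperazin-1-yl to 2-oxopiperazin-1-yl gives a 2.7-fold higher number from compound 1 to compound 3 (0.43 log units; beyond the scatter) and so shows that moving the carbonyl within the ring is enough for a modest shift at this place. The exchange of 4-isopropylpiperazin-1-yl for 2-oxopiperazin-1-yl gives a 1.7-fold higher number from compound 2 to compound 3 (0.23 log units; within the scatter) and leaves those two compounds unranked, even though the rings carry different groups. No measurement at hand explains why the place of the carbonyl matters.

Still open, as far as these compounds go, is whether this ring needs a carbonyl at all, which a plain piperazin-1-yl or a morpholine ring on the same chain carbon would test. Also open, from the compounds shown here alone, is whether any ring is needed there, which an open-chain amine such as dimethylamino would test.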